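Aryl variation on the shared core: compound 3 to compound 4

This account rests on a few compounds, and the source may have more. Where it says the series, first, only, none or still open, it means among the compounds named here.

Going by the values given here, in a functional assay on HeLa cells (Homo sapiens) for inhibition, read by MTT assay, with a stated time of 24 h (a lower number here means a stronger inhibitor, a higher number a weaker inhibitor), compound 3 `CCOC(=O)C1=Cc2ccccc2OC1(OCc1cc(-c2cccc(C(F)(F)F)c2)no1)C(F)(F)F` gives 21400 nM, the lowest number among the values so far; its nearest neighbour is compound 1 `CCOC(=O)C1=Cc2ccccc2OC1(OCc1cc(-c2ccc(Br)cc2)no1)C(F)(F)F`, which gives 52300 nM, the step being a 2.4-fold lower number from compound 1 to compound 3 (0.39 log units; beyond the scatter). Compound 2 `CCOC(=O)C1=Cc2ccccc2OC1(OCc1cc(-c2ccc3ccccc3c2)no1)C(F)(F)F` is reported only as a limit of the assay, > 150000 nM, as noted in the limit of > 150000 nM in this assay, at which 1 of the 3 values shown sits. From compound 2 the step runs an at least 7.0-fold lower number from compound 2 to compound 3 (0.84 log units; beyond the scatter), and from compound 1 to compound 2 it runs an at least 2.8-fold higher number from compound 1 to compound 2 (0.45 log units; beyond the scatter). Compound 4 `CCOC(=O)C1=Cc2ccccc2OC1(OCc1cc(-c2ccc(F)cc2)no1)C(F)(F)F` differs from compound 3 in one place: 4-fluorophenyl in place of 3-(trifluoromethyl)phenyl on an aromatic carbon. The measured steps that bear on this are the other aryl exchanges on the same carbon; the 4-bromophenyl of compound 1 against the 3-(trifluoromethyl)phenyl of compound 3 is the closest of them, a modest step, and the naphthalen-2-yl of compound 2 the widest. Since 4-fluorophenyl, like the 4-bromophenyl of compound 1, carries a single halogen, a modest rise in the number is expected, a 2.1-fold higher number from compound 3 to compound 4 (0.32 log units; beyond the scatter). Compound 4 is therefore estimated at 45000 nM, with a range from 18000 nM to 120000 nM.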

Compound 4, half-maximal inhibitory concentration: 42300 nM
Estimate against measurement, compound 4: 1.1-fold (0.03 log units) above; the measured number falls inside the stated range.
By their numbers in this assay, from the lowest: compounds 3, 4 and 1 (each within the scatter of the next, the first and the last beyond it). At a limit, above all of these: compound 2.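

In this assay, fluoro in place of bromo gives a 1.2-fold lower number from compound 1 to compound 4 (0.09 log units; within the scatter), and 4-fluorophenyl in place of 3-(trifluoromethyl)phenyl gives a 2.0-fold higher number from compound 3 to compound 4 (0.30 log units; within the scatter); both steps lie within the scatter, so the 4-fluorophenyl group cannot be separated from either neighbour, although those two neighbours lie beyond the scatter of each other. The exchange of naphthalen-2-yl for 4-fluorophenyl gives an at least 3.5-fold lower number from compound 2 to compound 4 (0.54 log units; beyond the scatter), so this second single-ring aryl group also stands clear of the fused aryl group. The entry for compound 2 is a limit, not a number: the limit of > 150000 nM in this assay, at which 1 of the 4 values shown sits.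

Going by these compounds, compound 3 and compound 4 differ in both the substituent and its place on the phenyl ring, so the effect of each alone remains open. A 4-(trifluoromethyl)phenyl or 3-fluorophenyl group would separate the two, and an amine or a carboxylic acid on the phenyl ring would test a different kind of substituent.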